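From Isopropyl to Fluoro at the Assay Limit

The source may report more compounds than this note shows. Statements on the series, on what has been measured and on what is new or still open speak of the compounds shown alone.

Compound 1 (`COc1cccc(NC(=O)Nc2ccc(Oc3ncnc4[nH]ncc34)cc2)c1`) and compound 2 (`CC(C)c1cccc(NC(=O)Nc2ccc(Oc3ncnc4[nH]ncc34)cc2)c1`) differ in one group, methoxy against isopropyl. In a functional assay on HeLa cells (Homo sapiens) for inhibition, read by MTT assay, with a stated time of 72 h (a lower number here means a stronger inhibitor, a higher number a weaker inhibitor), compound 1 gives > 10000 nM, which is a limit and not a number. In this assay compound 2 gives > 10000 nM, which is likewise a limit. Compound 2 therefore stands without a number, and the evidence so far amounts to the limit of > 10000 nM in this assay, at which 2 of the 2 values shown sit. For the measured compounds named here, the one measured step is a step that the two limits leave unreadable from compound 1 to compound 2, so it offers no size to carry forward.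

Compound 3 (`O=C(Nc1ccc(Oc2ncnc3[nH]ncc23)cc1)Nc1cccc(F)c1`) follows from compound 2 by fluoro in place of isopropyl on an aromatic carbon. This puts fluoro in place of isopropyl on an aromatic carbon, meta to a large group. Neither of the two groups measured on this carbon has yet yielded a number in this assay, so no step beyond the scatter is expected, and a further limit is the likeliest report. The estimated step is a step that the limit leaves unreadable from compound 2 to compound 3, an expectation set against a limit. For compound 3 the estimate is 12000 nM, with an expected range from 4000 nM to 30000 nM.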

Compound 3, half-maximal inhibitory concentration: > 10000 nM
Compound 3 was reported as a limit (the forecaster's own chance of this, stated with the estimate: 80%); the middle value is on the limit's open side.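

In this assay compound 3 gives > 10000 nM, which is a limit and not a number. None of the steps among compound 1, compound 2 and compound 3 can be read. The compounds shown leave open whether any group on this aromatic carbon would give a number in this assay, and how methoxy, isopropyl and fluoro compare there.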